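A few compounds are considered here, and "the series" means these few. Any claim that something is new, unique, unknown or untested is made for them only; others in the source may bear on it.

Measured so far:
compound 1 `O=C(O)CC(Cc1nc2cc(Cl)ccc2[nH]1)c1ccc(Cl)cc1` gives 70% in an assay on isolated protein for inhibition of protein kinase C zeta type (Homo sapiens), read by 33P incorporation, tested at 200 uM; a higher number here means a stronger effect of the compound at the concentration tested, a lower number a weaker effect;
compound 2 `O=C(O)CC(Cc1nc2cc(Br)ccc2[nH]1)c1ccc(Cl)cc1` gives 80% in this assay.

In this assay compound 2 sits beside compound 1 with no separation beyond the scatter: the step of a number 10 percentage points higher from compound 1 to compound 2 (within the scatter) came from a bromo group in place of a chloro group. Compound 3 `O=C(O)CC(Cc1nc2cc(C(F)(F)F)ccc2[nH]1)c1ccc(Cl)cc1` differs from compound 2 by trifluoromethyl in place of bromo on an aromatic carbon. For the measured compounds named here, no measured step involves a trifluoromethyl group, so only the halogen swap offers any guide, and it was small. For compound 3 I therefore expect a number close to that of compound 2, an estimated step of a number 5 percentage points lower from compound 2 to compound 3 (within the scatter) in this assay. My estimate for compound 3 is 75%, with a range from 55% to 92%.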

Compound 3, a percentage reported as inhibition, at one concentration (the size of the read-out at that concentration, not a potency): 85%
Compound 3: the middle estimate sits 10 percentage points below what was measured, within the range that was stated.
By their numbers in this assay, from the lowest: compounds 1, 2 and 3 (each within the scatter of the next, the first and the last beyond it).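

Trifluoromethyl, with four heavy atoms, is accepted at this aromatic carbon in this assay as readily as bromo, with one, giving a number 5 percentage points higher from compound 2 to compound 3 (within the scatter) and so no separation from the bromo compound. Against chloro, the same group gives a number 15 percentage points higher from compound 1 to compound 3 (beyond the scatter), the only separation beyond the scatter among these compounds, and a modest one. No measurement here accounts for that separation. Still open, as far as these compounds go, is whether a methoxy group, an amine or a nitrile at this carbon would keep the read-out this high, and how plain hydrogen there would compare.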